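Compound 2 to compound 4: methyl in place of phenyl

The source may report more compounds than this note shows. Statements on the series, on what has been measured and on what is new or still open speak of the compounds shown alone.

In an ADME assay on MDBK cells (Bos taurus) for cytotoxicity, read by MTT assay, with a stated time of 96 h (on this read-out lower numbers stand for higher toxicity in this test and higher numbers for lower toxicity in this test), compound 2 `c1ccc(/N=N/N2CCN(c3ccccc3)CC2)cc1` gives > 100000 nM, which is a limit. Compound 3 `c1ccc(/N=N/c2ccc(NC[C@@H]3CCCN4CCCC[C@H]34)c3c2CCCC3)cc1` gives > 100000 nM, also a limit. Going by the values given here, compound 1 `Fc1ccc(F)c(/N=N/c2ccc(NC[C@@H]3CCCN4CCCC[C@H]34)c3c2CCCC3)c1` gives 64000 nM, the only value in the set that is a number. On these data alone, compound 2 therefore stands at the limit of > 100000 nM in this assay, at which 2 of the 3 values shown sit, and its exact position is unknown.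

Compound 4 `CN1CCN(/N=N/c2ccccc2)CC1` comes from compound 2 through methyl in place of phenyl on an amine nitrogen in a ring. Among the compounds with values here, no measured step makes this exchange. The nearest guide is an at least 1.5-fold higher number from compound 1 to compound 3 (0.19 log units; that floor lies within the scatter), for phenyl in place of 2,5-difluorophenyl on a double-bonded nitrogen, and it bears only loosely on a change made elsewhere.

Compound 2 rests on the limit > 100000 nM, so no step beyond the scatter is expected in this assay, and another limit is the likely reading. The expected change is a number no higher from compound 2 to compound 4 (the limit leaves the size open). For compound 4 the estimate is 100000 nM, with an expected range of 40000 nM to 200000 nM.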

Compound 4, half-maximal cytotoxic concentration: > 100000 nM
Compound 4: a limit, no number (the forecaster's own chance of this, stated with the estimate: 70%); the middle value lies on the limit itself.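

In this assay compound 2 and compound 4 both give only limits, so no step between them can be read: the limit of > 100000 nM in this assay, at which 3 of the 4 values shown sit.

The compounds shown leave open whether methyl in place of phenyl on an amine nitrogen in a ring changes the read-out at all.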